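The source may report more compounds than this note shows. Statements on the series, on what has been measured and on what is new or still open speak of the compounds shown alone.

Measured in a functional assay on KYSE-70 cells for antiproliferative activity against KYSE-70 cell line (Homo sapiens), read by MTT assay, with a stated time of 72 h; a lower number here means a stronger inhibitor, a higher number a weaker inhibitor:
Compound 1 `COc1ccc(OC)c(NC(=O)c2cc(=O)[nH]c3cc(Br)ccc23)c1`: > 20000 nM
Compound 2 `O=C(Nc1cccc(C(F)(F)F)c1)c1cc(=O)[nH]c2cc(Br)ccc12`: > 20000 nM
Compound 3 `O=C(Nc1cccc(F)c1)c1cc(=O)[nH]c2cc(-c3ccc(F)cc3)ccc12`: 3300 nM

Compound 1 gives only a limit of the test, > 20000 nM, and not a number. Compound 2 likewise gives only a limit, > 20000 nM. The data are therefore thin, with the limit of > 20000 nM in this assay, at which 2 of the 3 values shown sit. For the measured compounds named here, compound 3, at 3300 nM, is the only compound here with an actual number in this assay, so it is the natural point of reference. Compounds 1 and 2 differ from compound 3 in more than one place, so they cannot show what a single change does.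

Compound 4 `O=C(Nc1cccc(F)c1)c1cc(=O)[nH]c2cc(-c3ccccc3F)ccc12` is compound 3 with one alteration: 2-fluorophenyl in place of 4-fluorophenyl on an aromatic carbon. The two compounds have the same atoms, joined differently. Going by the values given here, no measured pair here tests such a change, so the expectation rests on compound 3 at 3300 nM and on how small the alteration is. A small move in this assay seems most likely, leaning slightly towards weaker and possibly no larger than the usual scatter. The expected size of the change is a 1.4-fold higher number from compound 3 to compound 4 (0.13 log units; within the scatter). For compound 4 the estimated value is 4500 nM, with an expected range from 1800 nM to 12000 nM.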

Compound 4, half-maximal inhibitory concentration: > 20000 nM
Compound 4: only a limit was reported; the forecaster's own chance of this, stated with the estimate: 15%; middle value at least 4.4-fold (0.64 log units) from the limit.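

Moving the fluorine on this aromatic carbon, with the same atoms joined differently, from 4-fluorophenyl to 2-fluorophenyl gives an at least 6.0-fold higher number from compound 3 to compound 4 (0.78 log units; beyond the scatter) in this assay, so at this position the placement of one atom on the attached ring is enough to change the result beyond the scatter. Compound 4 gives > 20000 nM, which is a limit of the test and not a number. The printed step is therefore a lower bound on the true change, and compound 3 remains the only compound shown with an actual number, which leaves little room to grade the others: the limit of > 20000 nM in this assay, at which 3 of the 4 values shown sit.

The compounds shown leave open whether a plain phenyl group at this position would behave like the 4-fluorophenyl or the 2-fluorophenyl compound, and whether an amine or a carboxylic acid on that ring would restore or lower the activity. Also open, as far as these compounds go, is whether the same change would matter with another group on the amide nitrogen, as compound 1 and compound 2 differ from compound 3 in more than one place and cannot settle this.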